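Methoxyethyl in place of isopropyl on the ring amine

The compounds below may be only part of what the source reports. "The series", "measured", "known", "first", "only" and "open" are said of these compounds alone.

Compound 1 `CCN1CCc2c(sc(NC(=O)[C@@H]3CCCN3)c2C(N)=O)C1` reaches only the assay limit of > 25000 nM in a functional assay (strain AB) with Danio rerio as the target, read by microscopy, with a stated time of 1 h; a higher number here means that more compound is needed for the effect, a lower number that less compound is needed; this is a limit, not a number.
Compound 2 `CCN1CCc2c(sc(NC(=O)Nc3ccc(Br)cc3)c2C(N)=O)C1` gives 3130 nM in this assay.
Compound 3 `CC(C)CN1CCc2c(sc(NC(=O)Nc3ccc(Cl)cc3)c2C(N)=O)C1` gives 4510 nM in this assay.

Of the two numbers, compound 3 gives the higher one, with compound 2 within the scatter of it. Going by the values given here, the only computed step, an at least 7.9-fold lower number from compound 1 to compound 2 (0.90 log units; beyond the scatter), alters the group on the carbonyl carbon, a different place, so it offers no guide here. Compound 4 `COCCCN1CCc2c(sc(NC(=O)Nc3ccc(Cl)cc3)c2C(N)=O)C1` differs from compound 3 by 2-methoxyethyl in place of isopropyl on a saturated chain carbon bound to an amine nitrogen in a ring. Among the compounds with values here, no measured step touches the saturated chain carbon bound to the amine nitrogen in the ring, so no shift beyond the scatter is expected: a 1.0-fold lower number from compound 3 to compound 4 (0.00 log units; within the scatter). Compound 4 is therefore expected to give 4500 nM, somewhere between 2000 nM and 10000 nM.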

Compound 4, half-maximal effective concentration: 2400 nM
Estimate against measurement, compound 4: 1.9-fold (0.27 log units) above; the range from low to high includes it.
By their numbers in this assay, from the lowest: compounds 4, 2 and 3 (each within the scatter of the next). At a limit, above all of these: compound 1.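

In this assay, 2-methoxyethyl in place of isopropyl on a saturated chain carbon bound to an amine nitrogen in a ring gives a 1.9-fold lower number from compound 3 to compound 4 (0.27 log units; within the scatter). Going by these compounds alone, this is the first measured change at this position, and it shows that an added oxygen, a hydrogen-bond acceptor and one more heavy atom in the group leave the number within the scatter. Nothing on hand offers a cause for this result.

From the compounds shown here alone, an amine or a carboxylic acid on this chain remains open. So does a longer chain, since one tolerated change does not show how far this position can be varied.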